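A few compounds are considered here, and "the series" means these few. Any claim that something is new, unique, unknown or untested is made for them only; others in the source may bear on it.

Three compounds here share one core and differ in two places: the group on an amide-type nitrogen in a ring, and the substituent on an aromatic carbon of a six-membered aromatic ring with 1 nitrogen. In a functional assay on A-375 cells (Homo sapiens) for antiproliferative activity, read by MTT assay, with a stated time of 72 h (on this read-out lower numbers stand for stronger inhibition and higher numbers for weaker inhibition), compound 1 `COc1ccc(N2C(=O)COc3ccc(-c4cnc(OC)c(NS(=O)(=O)c5ccc(F)cc5)c4)cc32)cc1` gives 18400 nM. Compound 3 `O=C1COc2ccc(-c3cnc(Cl)c(NS(=O)(=O)c4ccc(F)cc4)c3)cc2N1c1ccc(Cl)cc1` gives 30600 nM in this assay. From the compounds shown here alone, for compound 2 `O=C1COc2ccc(-c3cnc(Cl)c(NS(=O)(=O)c4ccc(F)cc4)c3)cc2N1C1CCCCC1`, this assay reports only a limit, > 40000 nM; compound 2 thus sits at the limit of > 40000 nM in this assay, at which 1 of the 3 values shown sits, and its exact number is unknown. Among the compounds with values here, the single measured step, an at least 1.3-fold lower number from compound 2 to compound 3 (0.11 log units; that floor lies within the scatter), lies within the scatter.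

Compound 4 `COc1ncc(-c2ccc3c(c2)N(C2CCCCC2)C(=O)CO3)cc1NS(=O)(=O)c1ccc(F)cc1` differs from compound 2 by methoxy in place of chloro on an aromatic carbon. Within the data shown here, no measured step swaps these two groups alone. The pair that comes closest differs in two places at once: compound 1, with methoxy, shows 18400 nM, while compound 3, with chloro, shows 30600 nM, a gap that is itself small. Only this weak hint favours methoxy, and the cyclohexyl partner in compound 2 gave a limit rather than a number. A step from compound 2 to compound 4 of modest size toward a lower number is expected, but possibly none beyond the scatter, and the step of an at least 1.1-fold lower number from compound 2 to compound 4 (0.05 log units; that floor lies within the scatter) is estimated on that basis. Compound 4 is estimated at 35000 nM, with a range from 12000 nM to 100000 nM.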

Compound 4, half-maximal inhibitory concentration: > 40000 nM
Compound 4: no number, only a limit (the forecaster's own chance of this, stated with the estimate: 45%); middle value at least 1.1-fold (0.05 log units) from the limit.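

In this assay compound 4 gives only a limit, > 40000 nM. Within the data shown here, compound 2 also carries a limit, so the step for methoxy in place of chloro cannot be read, and this position, on an aromatic carbon next to the ring nitrogen, gains no measured swap of these two groups: the limit of > 40000 nM in this assay, at which 2 of the 4 values shown sit. What can be read concerns the amide-type nitrogen instead: cyclohexyl in place of 4-methoxyphenyl gives an at least 2.1-fold higher number from compound 1 to compound 4 (0.33 log units; beyond the scatter), the first step in this set that lies beyond the scatter, so the group on that nitrogen now shows a measurable effect on the read-out.

The compounds shown leave open whether methoxy and chloro differ at all on the carbon next to the ring nitrogen, as no pair with a real number on both sides swaps these two groups alone. Also open, from the compounds shown here alone, is how an amine or an ethoxy group on that carbon, or a butyl chain on the amide-type nitrogen, would read in this assay.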